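A few compounds are considered here, and "the series" means these few. Any claim that something is new, unique, unknown or untested is made for them only; others in the source may bear on it.

Working notes on the series, read in a functional assay on MDA-MB-231 cells (Homo sapiens) for cytotoxicity, read by MTT assay; a higher number here means a weaker inhibitor, a lower number a stronger inhibitor. Compound 1 `COc1cc(OC)cc(-c2cn(-c3ccc(Oc4ccccc4)cc3)nn2)c1` gives > 10000 nM, which is a limit of the assay and not a number. Compound 2 `COc1cc(-c2cn(-c3ccc(Oc4ccccc4)cc3)nn2)cc(OC)c1OC` gives 10000 nM. Compound 3 `COc1ccc(-c2cn(-c3ccc(Oc4ccccc4)cc3)nn2)cc1OC` gives 10000 nM. Compound 2 thus stands level with compound 3, and no measured value in the set is a number lower than these two.

The next structure is compound 4 `COc1cc(-c2cn(-c3ccc(OC(F)(F)F)cc3)nn2)cc(OC)c1OC`, reached through trifluoromethyl in place of phenyl on an oxygen on an aromatic ring, or phenoxy to trifluoromethoxy.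

Two measured steps are available, and both exchange methoxy and hydrogen on an aromatic carbon. The first is a number no higher from compound 1 to compound 2 (the limit leaves the size open), whose size the limit leaves open. The second is no change at the digits printed from compound 2 to compound 3 (within the scatter), which stays within the scatter. Neither touches the phenoxy group, so they bear on this change only indirectly, by showing a series that has so far barely moved in this assay.

No shift beyond the scatter is therefore expected, with only a slight lean towards a stronger value. The expected change is a 1.4-fold lower number from compound 2 to compound 4 (0.15 log units; within the scatter). For compound 4 the estimated value is 7000 nM, with an expected range of 2000 nM to 15000 nM.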

Compound 4, half-maximal inhibitory concentration: > 10000 nM
Compound 4: a limit, no number; the forecaster's own chance of this, stated with the estimate: 45%; middle value at least 1.4-fold (0.15 log units) away from the limit.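

In this assay compound 4 gives > 10000 nM, which is a limit of the assay and not a number. The step from phenoxy to trifluoromethoxy cannot be read for size, but it is the first change shown at this position, on an oxygen on an aromatic ring, and it gives no number lower than that of compound 2. The earlier steps exchanged only methoxy and hydrogen on an aromatic carbon, and the limit now restricts what can be read in this series as well: the limit of > 10000 nM in this assay, at which 2 of the 4 values shown sit.

The compounds shown leave open whether any replacement on this oxygen gives a clearly lower number in this assay, for example a chain ending in an amine or a carboxylic acid. They also leave open the size of the step from phenoxy to trifluoromethoxy, which reads as a number no lower from compound 2 to compound 4 (the limit leaves the size open).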